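The compounds below may be only part of what the source reports. "The series", "measured", "known", "first", "only" and "open" are said of these compounds alone.

Measured compounds:
Compound 1, `OC[C@H]1O[C@@H](n2cnc3c(NCc4ccc(Br)cc4)ncnc32)[C@H](O)[C@@H]1O`: > 166000 nM
Compound 2, `COc1cc(CNc2ncnc3c2ncn3[C@@H]2O[C@H](CO)[C@@H](O)[C@H]2O)cc(OC)c1`: > 166000 nM

Of the compounds shown here, two have so far been measured in a functional assay on MCF cells (Homo sapiens) for antiproliferative activity, with a stated time of 72 h; a lower number here means a stronger inhibitor, a higher number a weaker inhibitor. Compound 1 gives > 166000 nM in this assay, which is a limit of the assay and not a number. Compound 2 gives > 166000 nM in this assay, likewise a limit and not a number. Among the compounds with values here, the single measured step, a step that the two limits leave unreadable from compound 1 to compound 2, exchanged 3,5-dimethoxyphenyl for 4-bromophenyl on a saturated chain carbon bound to a nitrogen on an aromatic ring, and its size cannot be read from two limits. Compound 2 therefore stands at the limit, where both values shown sit, as the limit of > 166000 nM in this assay, at which 2 of the 2 values shown sit, records.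

Compound 3, `OC[C@H]1O[C@@H](n2cnc3c(NCc4cccc(C(F)(F)F)c4)ncnc32)[C@H](O)[C@@H]1O`, has not yet been measured. Its difference from compound 2 is 3-(trifluoromethyl)phenyl in place of 3,5-dimethoxyphenyl on a saturated chain carbon bound to a nitrogen on an aromatic ring. Within the data shown here, no measured step bears on this change with a readable size, so no direction can be drawn from the data beyond the fact that every value so far is a limit. The expected step in this assay is a step that the limit leaves unreadable from compound 2 to compound 3, an estimate resting only on those two limits. Compound 3 is therefore expected near 200000 nM, within 80000 nM to 600000 nM, with another limit the most probable report.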

Compound 3, half-maximal inhibitory concentration: > 166000 nM
Compound 3 was reported as a limit; the forecaster's own chance of this, stated with the estimate: 80%; the middle value is on the limit's open side.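

In this assay, within the data shown here, compound 3 gives > 166000 nM, a limit and not a number, so no step among compound 1, compound 2 and compound 3 can be read. The compounds shown leave open how the 4-bromophenyl, 3,5-dimethoxyphenyl and 3-(trifluoromethyl)phenyl groups compare, as all three compounds share one reported value: the limit of > 166000 nM in this assay, at which 3 of the 3 values shown sit.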